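The source may report more compounds than this note shows. Statements on the series, on what has been measured and on what is new or still open speak of the compounds shown alone.

Measured compounds:
- compound 1, `N[C@]1(C(=O)O)[C@H]2[C@@H](C[C@H]1OCc1ccccc1)[C@]2(F)C(=O)O`, in an assay on CHO cells for binding affinity to metabotropic glutamate receptor 2 (Rattus norvegicus) (on this read-out higher numbers stand for weaker inhibition and lower numbers for stronger inhibition), compound 1 gives 7.14 nM
- compound 2, `Nc1cccc(CO[C@@H]2C[C@@H]3[C@H]([C@]2(N)C(=O)O)[C@@]3(F)C(=O)O)c1`, in this assay compound 2 gives 15.4 nM

Compound 2 stands at the higher of the two numbers, with compound 1 as its nearest neighbour; the change a 2.2-fold higher number from compound 1 to compound 2 (0.33 log units; beyond the scatter) is modest but beyond the scatter.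

Compound 3, `N[C@]1(C(=O)O)[C@H]2[C@@H](C[C@H]1OCc1cc(Cl)ccc1Cl)[C@]2(F)C(=O)O`, has not yet been measured. It differs from compound 2 in one place: 2,5-dichlorophenyl in place of 3-aminophenyl on a saturated chain carbon bound to an oxygen on a saturated carbon. Among the compounds with values here, the only measured step that bears on a change at this position is a 2.2-fold higher number from compound 1 to compound 2 (0.33 log units; beyond the scatter), which shows that a single change on this aromatic ring shifts the number only modestly. Within the data shown here, no measured pair shows the effect of a chlorine here, so the direction of the step from compound 2 to compound 3 is uncertain. A small move, at most modest in size, is expected in this assay.

Compound 3 is therefore estimated at 10 nM, within a range of 3 nM to 35 nM, an expected step of a 1.5-fold lower number from compound 2 to compound 3 (0.19 log units; within the scatter).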

Compound 3, inhibition constant: 11.8 nM
Compound 3: the middle estimate sits 1.2-fold (0.07 log units) below what was measured; measured number inside the range.
By their numbers in this assay, from the lowest: compounds 1, 3 and 2 (each within the scatter of the next, the first and the last beyond it).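

In this assay, putting two chlorines on the ring at this position gives a step within the scatter on either comparison: a 1.3-fold lower number from compound 2 to compound 3 (0.12 log units; within the scatter) and a 1.7-fold higher number from compound 1 to compound 3 (0.22 log units; within the scatter). Compound 3 thus cannot be told apart from compound 1 or compound 2, even though those two differ beyond the scatter, so all three rings give numbers in the same narrow band, including 2,5-dichlorophenyl with no hydrogen-bond donors or acceptors and 3-aminophenyl with one of each. Nothing available explains why the numbers stay so close.

The compounds shown leave open whether either chlorine alone would give a similar number, since only the pair appears here. They also leave open how a carboxylic acid or a methoxy group on the ring, or a longer chain carrying the ring, would read.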